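From 3-Chlorophenyl to 4-Chlorophenyl in Compound 4

The source may hold more compounds than are shown below. What is called first, only, known or untested is meant among the compounds shown, and "the series" means these compounds.

Three close relatives have been measured in a toxicity assay on MT4 cells (Homo sapiens) for cytotoxicity, read by MTT assay; a lower number here means that less compound is tolerated, a higher number that more compound is tolerated. Compound 1 `Cc1cc(-c2ccccc2F)cc(C)c1Oc1cc(N)nc(Nc2ccc(C#N)cc2)n1` gives 29300 nM, compound 2 `Cc1cc(-c2cccc(F)c2)cc(C)c1Oc1cc(N)nc(Nc2ccc(C#N)cc2)n1` gives 24700 nM, and compound 3 `Cc1cc(-c2cccc(Cl)c2)cc(C)c1Oc1cc(N)nc(Nc2ccc(C#N)cc2)n1` gives 22300 nM. Compound 3 cannot be separated from the other two, with a 1.3-fold lower number from compound 1 to compound 3 (0.12 log units; within the scatter) and a 1.1-fold lower number from compound 2 to compound 3 (0.04 log units; within the scatter).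

Compound 4 `Cc1cc(-c2ccc(Cl)cc2)cc(C)c1Oc1cc(N)nc(Nc2ccc(C#N)cc2)n1` differs from compound 3 in one place: 4-chlorophenyl in place of 3-chlorophenyl on an aromatic carbon. This puts 4-chlorophenyl in place of 3-chlorophenyl on an aromatic carbon. The measured step closest in kind keeps the halogen and only moves it, giving a 1.2-fold lower number from compound 1 to compound 2 (0.07 log units; within the scatter). Exchanging fluoro for chloro gives a 1.1-fold lower number from compound 2 to compound 3 (0.04 log units; within the scatter). Among the measured compounds shown here, no measured compound carries the 4-chlorophenyl group, so these steps offer only an indirect guide. Since none of them exceeds the scatter, no change beyond the scatter is expected in this assay, and the estimated result is a 1.1-fold higher number from compound 3 to compound 4 (0.03 log units; within the scatter). The estimate for compound 4 is 24000 nM, with an expected range of 14000 nM to 40000 nM.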

Compound 4, half-maximal cytotoxic concentration: 21500 nM
Compound 4: middle estimate off by 1.1-fold (0.05 log units), on the high side; the range from low to high includes it.
By their numbers in this assay, from the lowest: compounds 4, 3, 2 and 1 (each within the scatter of the next).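

Moving the chlorine to give the 4-chlorophenyl group leaves the number in this assay within the scatter, with a 1.0-fold lower number from compound 3 to compound 4 (0.02 log units; within the scatter). The comparisons with the two fluorine-bearing relatives also stay within the scatter, with a 1.1-fold lower number from compound 2 to compound 4 (0.06 log units; within the scatter) and a 1.4-fold lower number from compound 1 to compound 4 (0.13 log units; within the scatter), so all four halogenated phenyl groups at this place, para to a large group, cannot be told apart in this assay. No measurement shown explains why these numbers stay so close.

On these data alone, whether an amine or a carboxylic acid on this phenyl ring would move the number beyond the scatter remains open. All four compounds carry a halogen on that ring, so the compounds shown also say nothing about a plain phenyl group or a methoxy group there.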